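From piperidin-1-yl to 3-methylpyrrolidin-1-yl on a potent antiproliferative compound

The source may hold more compounds than are shown below. What is called first, only, known or untested is meant among the compounds shown, and "the series" means these compounds.

For the measured compounds named here, in a functional assay on MCF7 cells (Homo sapiens) for antiproliferative activity, read by CellTiter-Glo, with a stated time of 5 days (a higher number here means a weaker inhibitor, a lower number a stronger inhibitor), compound 1 `CC1=C(c2cccc(O)c2)C(c2ccc(OC[C@H](C)N3CCCCC3)cc2)Oc2ccc(O)cc21` gives 0.1 nM, the lowest of the three numbers measured so far. Compound 3 `CC1=C(c2cccc(F)c2)C(c2ccc(OC[C@H](C)N3CC[C@@H](C)C3)cc2)Oc2ccc(O)cc21` gives 1 nM, and compound 2 `CC1=C(c2cccc(S(C)(=O)=O)c2)C(c2ccc(OC[C@H](C)N3CC[C@@H](C)C3)cc2)Oc2ccc(O)cc21` gives 4.3 nM. Compound 4 `CC1=C(c2cccc(O)c2)C(c2ccc(OC[C@H](C)N3CC[C@H](C)C3)cc2)Oc2ccc(O)cc21` is still unmeasured. It keeps the core of compound 1 and changes one group: 3-methylpyrrolidin-1-yl in place of piperidin-1-yl on a saturated chain carbon bound to two saturated chain carbons.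

Going by the values given here, no measured pair isolates this swap. Among the compounds with values here, the only single change measured, a 4.3-fold lower number from compound 2 to compound 3 (0.63 log units; beyond the scatter), sits on an aromatic carbon and leaves the 3-methylpyrrolidin-1-yl untouched, so it serves only as a guide to size. Compound 3 offers a further hint: it carries the mirror-image form of 3-methylpyrrolidin-1-yl and gives 1 nM, though it also has fluoro where compound 1 has hydroxy. A modest rise in the number, meaning a somewhat weaker inhibitor, therefore seems more likely than a fall. The expected change is a 3.0-fold higher number from compound 1 to compound 4 (0.48 log units; beyond the scatter). The estimate for compound 4 is 0.3 nM, with an expected range from 0.08 nM to 1.2 nM.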

Compound 4, half-maximal inhibitory concentration: 0.2 nM
Beside the measured number, compound 4's estimate is 1.5-fold (0.18 log units) above it, within the range that was stated.
By their numbers in this assay, from the lowest: compounds 1 and 4 (each within the scatter of the next); then compound 3; then compound 2.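

In this assay the swap at this saturated chain carbon gives a 2.0-fold higher number from compound 1 to compound 4 (0.30 log units; within the scatter) and so separates the two compounds by no more than repeat measurements would. For the compounds shown here, this is the first direct reading of this change: the six-membered piperidin-1-yl ring can give way to the five-membered 3-methylpyrrolidin-1-yl ring, with its defined stereocentre, without a difference this assay can resolve. The data shown include no measurement that could explain this result.

On these data alone, compound 3 carries the mirror-image form of 3-methylpyrrolidin-1-yl but also has fluoro in place of hydroxy, so the effect of that stereocentre alone stays open. Also open, as far as these compounds go, is how a plain pyrrolidin-1-yl ring or an open-chain amine such as diethylamino would behave in the same place.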